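Vero cell cytotoxicity: hydroxy for chloro on compound 1

The source may report more compounds than this note shows. Statements on the series, on what has been measured and on what is new or still open speak of the compounds shown alone.

Three members of this series have been run in an ADME assay on Vero cells (Chlorocebus sabaeus) for cytotoxicity, read by neutral red uptake, tested at 25 ug/mL; a lower number here means a stronger effect, a higher number a weaker effect of the compound at the concentration tested. Compound 1 `O=C1CSC(c2ccc(Cl)cc2)N1CCN1CCCCC1` gives 84% in this assay, compound 2 `COc1cccc(C2SCC(=O)N2CCN2CCCCC2)c1` gives 97%, and compound 3 `COc1ccccc1C1SCC(=O)N1CCN1CCCCC1` gives 100%. On these numbers compound 1 stands lowest of the three: the nearest value is that of compound 2, higher by a margin beyond the usual scatter, and the furthest is that of compound 3, again higher and beyond the scatter. For the measured compounds named here, all three read-outs nevertheless sit in the upper part of the scale, so none of the measured compounds shows more than a weak effect at the concentration tested.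

Compound 4 `O=C1CSC(c2ccc(O)cc2)N1CCN1CCCCC1` has not yet been measured. It differs from compound 1 in one place: hydroxy in place of chloro on an aromatic carbon. Going by the values given here, no measured pair in the set carries this same change, so nothing direct is known about how this assay answers it. Given that compound 1 already reads 84% and the two other measured compounds read higher still, the expectation for compound 4 is a step from compound 1 of a number 6 percentage points higher from compound 1 to compound 4 (within the scatter), upward but small, and likely not beyond the scatter. Compound 4 is therefore estimated at 90%, with a range from 76% to 100%.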

Compound 4, a percentage reported as activity, at one concentration (the size of the read-out at that concentration, not a potency): 100%
Beside the measured number, compound 4's estimate is 10 percentage points below it; measured number inside the range.
By their numbers in this assay, from the lowest: compound 1; then compounds 2, 3 and 4 (each within the scatter of the next).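

In this assay, for the compounds shown here, the change from 4-chlorophenyl to 4-hydroxyphenyl gives a number 16 percentage points higher from compound 1 to compound 4 (beyond the scatter), the first step that can be read at a single changed place. It shows that this place on an aromatic carbon, para to a large group, is not silent: with the rest of compound 1 held constant, exchanging chloro for hydroxy is enough to move the read-out beyond the scatter, although the step is only modest and compound 4 reads 100%. No measurement bearing on why the read-out moves accompanies this pair, so the step stands as an observation only, and the loss of chloro cannot be separated from the gain of hydroxy, with its hydrogen-bond donor and acceptor.

This single pair leaves open whether the lower read-out of compound 1 is particular to chloro or would also appear with another halogen such as bromo, or with a small carbon group such as methyl. It also leaves open how an amine or a carboxylic acid at the same place would read, and whether the same exchange would give a step of similar size on another member of the series.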